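This account rests on a few compounds, and the source may have more. Where it says the series, first, only, none or still open, it means among the compounds named here.

Working notes on the series

Three members have been measured in a functional assay on HCT-116 cells (Homo sapiens) for inhibition, read by MTT assay, with a stated time of 48 h; a higher number here means a weaker inhibitor, a lower number a stronger inhibitor. Compound 1, `COc1cc(NCc2ccccc2)cc(OC)c1OC`, returns only a limit of the assay in this assay, > 80000 nM. Among the compounds with values here, compound 2, `COc1ccc(CN(C(=O)C=C(C)C)c2cc(OC)c(OC)c(OC)c2)cc1O`, gives 290 nM in this assay, the lowest of the two numbers so far; the nearest value is that of compound 3, `C/C=C/C(=O)N(Cc1ccc(OC)c(Cl)c1)c1cc(OC)c(OC)c(OC)c1`, which gives 1420 nM in this assay, a gap beyond the scatter. Within the data shown here, the limit of > 80000 nM in this assay, at which 1 of the 3 values shown sits, is the only other information.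

The next member is compound 4, `COc1ccc(CN(C(=O)C(C)Br)c2cc(OC)c(OC)c(OC)c2)cc1O`, still to be measured in this assay. It differs from compound 2 in one place: 1-bromoethyl in place of 2-methylprop-1-en-1-yl on a carbonyl carbon. Among the measured compounds shown here, no pair of measured compounds shows this change, so its size in this assay is open. A step of moderate size is expected, in the direction of a higher number, but not far beyond the scatter, so the step from compound 2 to compound 4 is estimated as a 2.1-fold higher number from compound 2 to compound 4 (0.32 log units; beyond the scatter). For compound 4 the expected value in this assay is 600 nM, between 150 nM and 2500 nM.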

Compound 4, half-maximal inhibitory concentration: 140 nM
The estimate for compound 4 lay 4.3-fold (0.63 log units) above the measured number, outside the stated range (below it).
By their numbers in this assay, from the lowest: compound 4; then compound 2; then compound 3. At a limit, above all of these: compound 1.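

In this assay, 1-bromoethyl in place of 2-methylprop-1-en-1-yl on a carbonyl carbon gives a 2.1-fold lower number from compound 2 to compound 4 (0.32 log units; beyond the scatter), the first step read at this place in the series. In this pair, the double bond outside aromatic rings is therefore not needed for a low number, and a group carrying bromine is accepted on the carbonyl carbon whose other neighbour is the amide-type nitrogen. No measurement in hand bears on the reason for this step.

From the compounds shown here alone, whether the lower number follows the bromine or the loss of the double bond stays open, and a 1-chloroethyl group, an ethyl group or a longer chain at this carbon would separate the two. Also open, going by these compounds, is whether the same change holds in the setting of compound 3.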